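The source may report more compounds than this note shows. Statements on the series, on what has been measured and on what is new or still open speak of the compounds shown alone.

Compound 3 `CC(C)C(=O)Nc1ccc(S(=O)(=O)Oc2ccccc2I)cc1` gives 3300 nM in a functional assay on HT-1080 cells (Homo sapiens) for antiproliferative activity, read by sulforhodamine B assay, with a stated time of 48 h; a higher number here means a weaker inhibitor, a lower number a stronger inhibitor. Compound 1 `CCC(=O)Nc1ccc(S(=O)(=O)Oc2ccccc2I)cc1` gives 7200 nM and compound 2 `CCCC(=O)Nc1ccc(S(=O)(=O)Oc2ccccc2I)cc1` gives 2000 nM, so compound 3 stands second highest of the three numbers, and its gap to compound 2 lies within the scatter. Compound 4 `O=C(CCl)Nc1ccc(S(=O)(=O)Oc2ccccc2I)cc1` differs from compound 3 by chloromethyl in place of isopropyl on a carbonyl carbon. The measured steps only vary the alkyl on the carbonyl: a 3.6-fold lower number from compound 1 to compound 2 (0.56 log units; beyond the scatter), a 2.2-fold lower number from compound 1 to compound 3 (0.34 log units; beyond the scatter) and a 1.7-fold higher number from compound 2 to compound 3 (0.22 log units; within the scatter). None of them brings in a chlorine, so they bear only loosely on this change, and no step beyond the scatter is expected in either direction. The step from compound 3 to compound 4 is therefore estimated as a 1.2-fold higher number from compound 3 to compound 4 (0.08 log units; within the scatter). Compound 4 is expected to give 4000 nM, with a range from 1000 nM to 16000 nM.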

Compound 4, half-maximal inhibitory concentration: 600 nM
Beside the measured number, compound 4's estimate is 6.7-fold (0.82 log units) above it, outside the stated range (below it).
By their numbers in this assay, from the lowest: compound 4; then compounds 2 and 3 (each within the scatter of the next); then compound 1.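

In this assay, chloromethyl on the carbonyl carbon gives a 5.5-fold lower number from compound 3 to compound 4 (0.74 log units; beyond the scatter), together with a 3.3-fold lower number from compound 2 to compound 4 (0.52 log units; beyond the scatter) and a 12-fold lower number from compound 1 to compound 4 (1.08 log units; beyond the scatter). Compound 4 therefore sits beyond the scatter from all three alkyl compounds, showing that this position can respond to more than a change of alkyl group. Nothing available gives a reason for this gain. As far as these compounds go, it remains open whether the gain belongs to chlorine in particular or would also appear with bromomethyl, dichloromethyl or plain methyl on the same carbonyl carbon.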